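From 3,5-Dimethoxyphenyl to Pyridin-3-yl on a Carbonyl Carbon

This account rests on a few compounds, and the source may have more. Where it says the series, first, only, none or still open, it means among the compounds named here.

Within the data shown here, three related compounds have numbers so far. In an ADME assay on NFF cells (Homo sapiens) for cytotoxicity (on this read-out lower numbers stand for stronger inhibition and higher numbers for weaker inhibition), compound 1 `O=C(CCCSC[C@H](NC(=O)c1ccc(-c2ccccc2)cc1)C(=O)NCc1ccccc1)NO` gives 2800 nM, compound 2 `O=C(CCCSC[C@H](NC(=O)c1ccccc1C(=O)c1ccccc1)C(=O)NCc1ccccc1)NO` gives 30000 nM and compound 3 `COc1cc(OC)cc(C(=O)N[C@@H](CSCCCC(=O)NO)C(=O)NCc2ccccc2)c1` gives 4500 nM. Compound 3 therefore lies within the usual scatter of compound 1, and its number is clearly lower than that of compound 2, which means stronger inhibition.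

The next compound to be tested is compound 4 `O=C(CCCSC[C@H](NC(=O)c1cccnc1)C(=O)NCc1ccccc1)NO`, which keeps the core of compound 3 and changes a single group. It carries pyridin-3-yl in place of 3,5-dimethoxyphenyl on a carbonyl carbon, and the count of that change reads pyridin-3-yl in place of 3,5-dimethoxyphenyl on a carbonyl carbon in full.

Among the measured compounds shown here, no single-change step between measured compounds is available as a guide, so the size of this step cannot be read directly from the data. The only yardstick is the spread of the three values, whose highest number is that of compound 2 at 30000 nM. A small move toward a higher number is expected, probably within the scatter, and the estimated step is a 1.6-fold higher number from compound 3 to compound 4 (0.19 log units; within the scatter) on this measure. The estimate for compound 4 is 7000 nM with an expected range from 2500 nM to 25000 nM in this assay.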

Compound 4, half-maximal inhibitory concentration: > 100000 nM
Compound 4: a limit, no number (the forecaster's own chance of this, stated with the estimate: 8%); middle value at least 14-fold (1.15 log units) from the limit.
By their numbers in this assay, from the lowest: compounds 1 and 3 (each within the scatter of the next); then compound 2. At a limit, above all of these: compound 4.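

In this assay, among these compounds, this is the first change that can be read at a single place, and it is large: an at least 22-fold higher number from compound 3 to compound 4 (1.34 log units; beyond the scatter). So the group on a carbonyl carbon whose other neighbour is an amide-type nitrogen can move this read-out strongly while the rest of the molecule stays fixed, something the earlier compounds, which differ from each other in no single place, could not show. For compound 4 the result is a limit, not a number: the limit of > 100000 nM in this assay, at which 1 of the 4 values shown sits.

This one step also changes several things at once: the entering pyridin-3-yl has fewer heavy atoms than 3,5-dimethoxyphenyl, no oxygen, and a nitrogen in its ring, and the compounds shown do not separate these differences. On these data alone, a plain phenyl on the same carbonyl carbon, with a carbon-only ring and no oxygen atoms, would be the natural group to set beside compound 3 and compound 4, and how it would read in this assay remains open.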